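The source may hold more compounds than are shown below. What is called first, only, known or untested is meant among the compounds shown, and "the series" means these compounds.

The measured compounds are three. In an ADME assay on HepG2 cells (Homo sapiens) for inhibition, with a stated time of 72 h (on this read-out lower numbers stand for an effect already at smaller amounts and higher numbers for an effect only at larger amounts of compound), compound 1 `CN(C)CCC(=O)Nc1cccc(-c2nc3ccccc3s2)c1` gives 21000 nM. Compound 2 `O=C(CCl)Nc1cccc(-c2nc3ccccc3s2)c1` gives 16000 nM in this assay. For compound 3 `CC(Cl)C(=O)Nc1cccc(-c2nc3ccccc3s2)c1` this assay reports only a limit, > 25000 nM.

Compound 3 therefore stands at the limit of > 25000 nM in this assay, at which 1 of the 3 values shown sits, and no number is known for it. The steps that reach it are an at least 1.1-fold higher number from compound 1 to compound 3 (0.07 log units; that floor lies within the scatter) and an at least 1.5-fold higher number from compound 2 to compound 3 (0.19 log units; that floor lies within the scatter); the remaining step among the measured compounds, a 1.3-fold lower number from compound 1 to compound 2 (0.12 log units; within the scatter), is of the same kind. None of the three steps crosses the scatter, and none of them exchanges the chain on the carbonyl carbon for a ring.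

Compound 4 `O=C(Nc1cccc(-c2nc3ccccc3s2)c1)c1cnccc1Cl` is not yet measured. It differs from compound 3 in that (4-chloropyridin-3-yl in place of 1-chloroethyl on a carbonyl carbon). No measured step resembles this exchange, so its size cannot be read from the steps shown; what they show is that the three variations of the group on the carbonyl carbon stayed within the scatter of one another. The step of a number no higher from compound 3 to compound 4 (the limit leaves the size open) is accordingly expected to lie within the scatter, though the starting point is known only as a limit, which leaves the expectation loose. Compound 4 is estimated at 25000 nM, in a range from 9000 nM to 70000 nM.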

Compound 4, half-maximal effective concentration: > 25000 nM
Compound 4: no number, only a limit; the forecaster's own chance of this, stated with the estimate: 55%; the middle value sits exactly at the limit.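

With 4-chloropyridin-3-yl on the carbonyl carbon, the group there is for the first time a ring rather than a chain, and in this assay compound 4 gives a limit and no number, as compound 3 does: the limit of > 25000 nM in this assay, at which 2 of the 4 values shown sit.

Measured against the two compounds that have numbers, the steps are an at least 1.5-fold higher number from compound 2 to compound 4 (0.19 log units; that floor lies within the scatter) and an at least 1.1-fold higher number from compound 1 to compound 4 (0.07 log units; that floor lies within the scatter), so neither step shows that the ring separates compound 4 from the chains of compound 1 and compound 2. The step between compound 3 and compound 4 cannot be read, since both ends are limits.

On these data alone, how far the true values of compound 3 and compound 4 lie past the limit stays open, and with it the size of the exchange of 1-chloroethyl for 4-chloropyridin-3-yl. Also open, as far as these compounds go, is whether a plain phenyl ring, a carboxylic acid or a longer chain on the carbonyl carbon would give a number clearly apart from the others in this assay.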